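The source may hold more compounds than are shown below. What is called first, only, known or untested is meant among the compounds shown, and "the series" means these compounds.

Within a functional assay for agonist activity at G protein-coupled receptor 88 (Homo sapiens), read by HTRF and cAMP accumulation (a lower number here means that less compound is needed, a higher number that more compound is needed for the effect), compound 2, whose structure is `CC(C)C[C@@H](N)CN(C(=O)[C@@H]1C[C@H]1c1ccccc1)c1ccc(-c2ccccc2)cc1`, gives 1.8 nM and shows the lowest number of the three compounds that have been measured. Its closest neighbour is compound 3, `CCC(CC)C(N)CCN(C(=O)[C@@H]1C[C@H]1c1ccccc1)c1ccc(-c2ccccc2)cc1`, which gives 2 nM; the step of a 1.1-fold higher number from compound 2 to compound 3 (0.05 log units; within the scatter) lies within the scatter. The most distant is compound 1, `CC(C)C[C@H](N)CN(C(=O)[C@@H]1C[C@H]1c1ccccc1)c1ccc(-c2ccccc2)cc1`, which gives 880 nM; the step of a 490-fold lower number from compound 1 to compound 2 (2.69 log units; beyond the scatter) is large, and this pair rests on (the fact that compounds 1 and 2 differ only in the configuration as drawn).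

Compound 4, `O=C([C@@H]1C[C@H]1c1ccccc1)N(CCNCC1CCCC1)c1ccc(-c2ccccc2)cc1`, has not yet been measured. Compared with compound 2 the change is ((cyclopentylmethyl)amino)methyl in place of 1-amino-3-methylbutyl on a saturated chain carbon bound to an amide-type nitrogen. The part that leaves carries the one defined stereocentre, so the configuration that separated compound 1 from compound 2 no longer exists in compound 4.

Among the compounds with values here, two measured steps bear on this change. The step of a 1.1-fold higher number from compound 2 to compound 3 (0.05 log units; within the scatter) shows that reshaping and lengthening the amine-bearing chain, as in 2-amino-3-ethylpentyl, barely moved the number. The step of a 490-fold lower number from compound 1 to compound 2 (2.69 log units; beyond the scatter) shows how strongly the number depended on configuration at that chain carbon, a dependence that compound 4 cannot show. A modest step is therefore expected, a 3.3-fold higher number from compound 2 to compound 4 (0.52 log units; beyond the scatter), with wide uncertainty. The number for compound 4 in this assay is estimated at 6 nM, within a range from 1.2 nM to 35 nM.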

Compound 4, half-maximal effective concentration: 2.5 nM
For compound 4 the middle estimate is 2.4-fold (0.38 log units) above the measured one; low and high end bracket the measured number.
By their numbers in this assay, from the lowest: compounds 2, 3 and 4 (each within the scatter of the next); then compound 1.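

In this assay, ((cyclopentylmethyl)amino)methyl can take the place of 1-amino-3-methylbutyl with no change that stands out from the scatter, and the group that enters brings a five-membered ring of carbon only and no defined stereocentre: a 1.4-fold higher number from compound 2 to compound 4 (0.14 log units; within the scatter). The comparison with the reshaped chain of compound 3 reads the same way, a 1.3-fold higher number from compound 3 to compound 4 (0.10 log units; within the scatter), so a low number at this position does not depend on a defined stereocentre in this group, nor on a free chain without a ring. Compound 1 remains the outlier, a 350-fold lower number from compound 1 to compound 4 (2.55 log units; beyond the scatter), so the earlier gap now looks like a penalty tied to one drawn configuration, not a requirement for the other, and the pair behind that gap is clean: the fact that compounds 1 and 2 differ only in the configuration as drawn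

Whether the cyclopentyl ring itself matters remains open, as the shown compounds offer no cyclohexylmethyl, benzyl or open isobutyl group on the same nitrogen for comparison. All four compounds also carry an amine in this chain, which leaves open what a hydroxyl group or an ether oxygen would give there.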